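Replacing the phenyl group of compound 2

The source may report more compounds than this note shows. Statements on the series, on what has been measured and on what is new or still open speak of the compounds shown alone.

Compound 1 `Cc1nn(-c2ccccc2)c(Oc2ccc(-c3nc4cc([N+](=O)[O-])ccc4[nH]3)cc2)c1/C=N/NC(N)=S`: 9200 nM
Compound 2 `Cc1nn(-c2ccccc2)c(Oc2ccc(-c3nc4cc(C(=O)O)ccc4[nH]3)cc2)c1/C=N/Nc1ccccc1`: 17700 nM

In a functional assay on MCF7 cells (Homo sapiens) for cytotoxicity, read by sulforhodamine B assay, with a stated time of 48 h (a lower number here means a stronger inhibitor of growth, a higher number a weaker inhibitor of growth), compound 2 gives 17700 nM, and compound 1 gives 9200 nM. These two values lie within the usual scatter of each other, so compound 2 cannot be separated from compound 1 on these numbers.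

The next compound to be measured is compound 3 `Cc1nn(-c2ccccc2)c(Oc2ccc(-c3nc4cc(C(=O)O)ccc4[nH]3)cc2)c1/C=N/NC(N)=S`. Its change from compound 2 is a group of 3 heavy atoms (1 carbon, 1 nitrogen, 1 sulfur; no ring) in place of a group of 6 heavy atoms (6 carbon; one six-membered aromatic ring of carbon only), on an amine nitrogen. A phenyl group leaves an amine nitrogen, and a smaller group with no ring takes its place.

Among the measured compounds shown here, no measured pair shows the effect of this change, so the expectation is necessarily broad. In this assay, no step beyond the scatter is expected. The estimated 1.6-fold lower number from compound 2 to compound 3 (0.21 log units; within the scatter) points slightly towards a lower number. For compound 3 the expected value is 11000 nM, with an estimated range from 3500 nM to 32000 nM.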

Compound 3, concentration for 50% growth inhibition: 18100 nM
The estimate for compound 3 lay 1.6-fold (0.22 log units) below the measured number, within the range that was stated.
By their numbers in this assay, from the lowest: compounds 1, 2 and 3 (each within the scatter of the next).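

In this assay, the group with no ring in place of the phenyl group on the amine nitrogen gives a 1.0-fold higher number from compound 2 to compound 3 (0.01 log units; within the scatter), so at this position the six-membered aromatic ring can be lost with no readable shift in the number. Among the compounds shown here, the other step, carboxy in place of nitro on an aromatic carbon, gives a 2.0-fold higher number from compound 1 to compound 3 (0.29 log units; within the scatter), the first direct reading of that place on the shared core, and it also stays inside the scatter. No measurement on these compounds offers any explanation of either result.

Going by these compounds, it remains open whether an amine or a longer chain on the amine nitrogen would produce a step beyond the scatter. The same question stands for an amide in place of carboxy on the aromatic carbon.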